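A few compounds are considered here, and "the series" means these few. Any claim that something is new, unique, unknown or untested is made for them only; others in the source may bear on it.

Compound 3, whose structure is `Nc1nc(NCCNc2ncc(-c3ncc[nH]3)c(-c3ccc(Br)cc3F)n2)ccc1[N+](=O)[O-]`, was tested in an ADME assay on microsomes from liver (Canis lupus familiaris) for metabolic stability; a lower number here means that the compound disappears faster, a higher number that the compound lasts longer. In this assay compound 3 gives > 0.5 h, which is a limit of the assay rather than a measured number. Two related compounds sit at the same limit. Compound 1, with the structure `N#Cc1ccc(-c2nc(NCCNc3ccc([N+](=O)[O-])c(N)n3)ncc2-c2ncc[nH]2)cc1`, gives > 0.5 h in this assay, again a limit. Compound 2, with the structure `Nc1nc(NCCNc2ncc(-c3ncc[nH]3)c(-c3cc(F)ccc3F)n2)ccc1[N+](=O)[O-]`, gives > 0.5 h in this assay, also a limit. Because of the limit of > 0.5 h in this assay, at which 3 of the 3 values shown sit, none of the steps among these three can be sized: the step that the two limits leave unreadable from compound 1 to compound 2, the step that the two limits leave unreadable from compound 1 to compound 3 and the step that the two limits leave unreadable from compound 2 to compound 3 are all unreadable, since a limit on each side hides how far apart the true numbers lie.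

The compound not yet measured is compound 4, with the structure `COc1cc(Cl)ccc1-c1nc(NCCNc2ccc([N+](=O)[O-])c(N)n2)ncc1-c1ncc[nH]1`. It differs from compound 3 in one place: 4-chloro-2-methoxyphenyl in place of 4-bromo-2-fluorophenyl on an aromatic carbon. Within the data shown here, no measured step shows what this kind of exchange does in this assay, so nothing points to a change in either direction. The expectation for the step that the limit leaves unreadable from compound 3 to compound 4 is therefore that it stays within the scatter of the measurement. Compound 4 is estimated to give 1 h in this assay, expected to fall between 0.4 h and 3 h, most likely reported again only as the same limit.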

Compound 4, half-life: > 0.5 h
Compound 4 was reported as a limit; the forecaster's own chance of this, stated with the estimate: 70%; the middle value lies beyond the limit too.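

In this assay compound 4 gives > 0.5 h, which is a limit of the assay and not a measured number. Among these compounds, no step between compound 4 and compound 1, compound 2 or compound 3 can be read, because all four compounds share one limit: the limit of > 0.5 h in this assay, at which 4 of the 4 values shown sit. The compounds shown leave open how long each one truly lasts and whether exchanging the phenyl group changes that at all.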